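A Bulkier Branch on the Carbamate Side Chain

The source may report more compounds than this note shows. Statements on the series, on what has been measured and on what is new or still open speak of the compounds shown alone.

Four compounds share one core and differ only in the group carried on the side-chain oxygen. Compound 1, `COc1cc(C(=O)N2CCN(C(=O)c3cc(OC)c(OC)c(OC)c3)C(COC(=O)C(C)(C)C)C2)cc(OC)c1OC`, in a functional assay (Oryctolagus cuniculus) for inhibition of platelet-activating factor receptor (Cavia porcellus) (on this read-out higher numbers stand for weaker inhibition and lower numbers for stronger inhibition), gives 100 nM; 100 nM; 120 nM (3 entries), and the closeness of these repeats, (the several entries of compound 1 in this assay, 100 nM; 100 nM; 120 nM (3 entries)), shows how steady this read-out is. Compound 2, `COc1cc(C(=O)N2CCN(C(=O)c3cc(OC)c(OC)c(OC)c3)C(COC(=O)C3CCCCC3)C2)cc(OC)c1OC`, in this assay gives 290 nM. Within the data shown here, compound 3, `CCCC(C)NC(=O)OCC1CN(C(=O)c2cc(OC)c(OC)c(OC)c2)CCN1C(=O)c1cc(OC)c(OC)c(OC)c1`, in this assay gives 100 nM, the lowest of the two single numbers; the nearest other number is that of compound 2, and the only measured step, a 2.9-fold lower number from compound 2 to compound 3 (0.46 log units; beyond the scatter), puts (1-methylbutyl)amino in place of cyclohexyl on the carbonyl carbon.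

Compound 4, `COc1cc(C(=O)N2CCN(C(=O)c3cc(OC)c(OC)c(OC)c3)C(COC(=O)NC(C)C(C)(C)C)C2)cc(OC)c1OC`, differs from compound 3 by tert-butyl in place of propyl on a saturated chain carbon bound to an amide-type nitrogen and a saturated chain carbon. The measured step from compound 2 to compound 3 changes the kind of link to the carbonyl, not the branching of the alkyl chain, so it does not bear directly on this change. Nothing measured here points to a direction, so no step beyond the scatter is expected. Compound 4 is therefore expected to give 110 nM, with a range from 50 nM to 250 nM. The step this estimate implies, a 1.1-fold higher number from compound 3 to compound 4 (0.04 log units; within the scatter), is expected to stay within the scatter.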

Compound 4, half-maximal inhibitory concentration: 170 nM
Beside the measured number, compound 4's estimate is 1.5-fold (0.19 log units) below it; measured number inside the range.
By their numbers in this assay, from the lowest: compounds 3, 4 and 2 (each within the scatter of the next, the first and the last beyond it).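

In this assay, tert-butyl in place of propyl on a saturated chain carbon bound to an amide-type nitrogen and a saturated chain carbon gives a 1.7-fold higher number from compound 3 to compound 4 (0.23 log units; within the scatter), so this part of the side chain accepts the change without a shift that can be told apart from ordinary variation. The other new step, a 1.7-fold lower number from compound 2 to compound 4 (0.23 log units; within the scatter), puts (1,2,2-trimethylpropyl)amino in place of cyclohexyl on a carbonyl carbon and also stays within the scatter, unlike a 2.9-fold lower number from compound 2 to compound 3 (0.46 log units; beyond the scatter), so the clear gain seen with the earlier side chain is not clearly repeated with this one. Small gaps like these are best read with the steadiness of the read-out in mind: the several entries of compound 1 in this assay, 100 nM; 100 nM; 120 nM (3 entries)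

The compounds shown leave open how much further this position can be pushed, for instance whether a phenyl ring or a longer chain such as hexyl, or an amine or carboxylic acid at the chain end, would move the number beyond the scatter. Among these compounds, no two compounds here carry the same alkyl group on both an ester and a carbamate link, so the effect of the link alone also remains unsettled.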